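The source may hold more compounds than are shown below. What is called first, only, known or untested is meant among the compounds shown, and "the series" means these compounds.

Compound 1 `COC(OC)c1cn(C2C[C@H](OC(C)=O)[C@@H](COC(C)=O)O2)c(=O)[nH]c1=O` and compound 2 `CC(=O)OC[C@H]1OC(n2cc(C3OCCO3)c(=O)[nH]c2=O)C[C@@H]1OC(C)=O` share one core and differ in a single group on an aromatic carbon. In a functional assay on HFF cells (Homo sapiens) for cytotoxicity, read by neutral red uptake (a higher number here means that more compound is tolerated, a lower number that less compound is tolerated), compound 1 gives > 300000 nM, which is a limit of the assay and not a number. In this assay compound 2 gives > 300000 nM, which is likewise only a limit. Compound 2 therefore has no numeric standing, and the record so far consists of the limit of > 300000 nM in this assay, at which 2 of the 2 values shown sit.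

Compound 3 `CC(=O)OC[C@H]1OC(n2cc(C3OCCCO3)c(=O)[nH]c2=O)C[C@@H]1OC(C)=O` keeps the core and changes that same group: a group of 6 heavy atoms (4 carbon, 2 oxygen; one six-membered non-aromatic ring with 2 hetero atoms) in place of a group of 5 heavy atoms (3 carbon, 2 oxygen; one five-membered non-aromatic ring with 2 hetero atoms), on an aromatic carbon. A group with a six-membered non-aromatic ring thus replaces 1,3-dioxolan-2-yl on an aromatic carbon. Within the data shown here, the one measured step bearing on this change is a step that the two limits leave unreadable from compound 1 to compound 2, and it offers no size to carry forward. On that basis, no step beyond the usual scatter is expected in this assay, in either direction, and another limit is the likeliest report. The estimated change is a number no higher from compound 2 to compound 3 (the limit leaves the size open). For compound 3 the estimated value is 300000 nM, with an expected range from 150000 nM to 600000 nM.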

Compound 3, half-maximal cytotoxic concentration: > 300000 nM
Compound 3: only a limit was reported (the forecaster's own chance of this, stated with the estimate: 85%); the middle value lies on the limit itself.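

In this assay compound 3 gives > 300000 nM, which is a limit of the assay and not a number. Among these compounds, no step among compound 1, compound 2 and compound 3 can therefore be read. The compounds shown leave open the concentration at which any of the three becomes cytotoxic, and whether the changed group matters there: the limit of > 300000 nM in this assay, at which 3 of the 3 values shown sit.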